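Hydroxy in place of nitro in the ethyl ester series

A few compounds are considered here, and "the series" means these few. Any claim that something is new, unique, unknown or untested is made for them only; others in the source may bear on it.

compound 1 `CCOC(=O)c1cc(-c2cc(OC)c(OC)c(OC)c2)c(-c2ccc(OC)c(O)c2)s1` gives 1580 nM
compound 2 `COc1ccc(-c2sc(C(=O)O)cc2-c2cc(OC)c(OC)c(OC)c2)cc1` gives 7800 nM
compound 3 `CCOC(=O)c1cc(-c2ccc(OC)c([N+](=O)[O-])c2)c(-c2cc(OC)c(OC)c(OC)c2)s1` gives 19400 nM

All three values come from a functional assay on SGC-7901 cells (Homo sapiens) for antiproliferative activity, read by MTT assay, with a stated time of 72 h (on this read-out higher numbers stand for weaker inhibition and lower numbers for stronger inhibition), and compound 3 has the highest number at 19400 nM with both other compounds lower by more than the scatter. Compound 4 `CCOC(=O)c1cc(-c2ccc(OC)c(O)c2)c(-c2cc(OC)c(OC)c(OC)c2)s1` differs from compound 3 by hydroxy in place of nitro on an aromatic carbon, ortho to a methoxy group hydroxy in place of nitro on an aromatic carbon and so carries 3-hydroxy-4-methoxyphenyl instead of 4-methoxy-3-nitrophenyl. Going by the values given here, no step between measured compounds isolates this change. Compound 1 also carries a hydroxy group and an ethyl ester and gives 1580 nM in this assay so a lower number is expected for compound 4. The expected change is a 9.7-fold lower number from compound 3 to compound 4 (0.99 log units; beyond the scatter) which is estimated as a large step toward stronger inhibition, beyond the scatter. For compound 4 the estimated value is 2000 nM with an expected range from 300 nM to 12000 nM in this series.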

Compound 4, half-maximal inhibitory concentration: 20000 nM
Compound 4: middle estimate off by 10-fold (1.00 log units), on the low side; measured number outside the range, above it.
By their numbers in this assay, from the lowest: compound 1; then compound 2; then compounds 3 and 4 (each within the scatter of the next).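

In this assay hydroxy in place of nitro on an aromatic carbon, ortho to a methoxy group, leaves the number within the scatter (a 1.0-fold higher number from compound 3 to compound 4 (0.01 log units; within the scatter)). At this position of the ethyl ester series, 4-methoxy-3-nitrophenyl and 3-hydroxy-4-methoxyphenyl therefore cannot be told apart, so the hydroxy group alone does not mark out a stronger compound here. No available measurement explains this result. Going by these compounds, whether an amine or a fluorine atom at this position would separate from nitro and hydroxy remains open. So does whether a carboxylic acid in place of the ethyl ester would change the picture for compound 4.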